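The source may report more compounds than this note shows. Statements on the series, on what has been measured and on what is new or still open speak of the compounds shown alone.

Working notes on the series, starting from compound 3 (`COC(=O)CNC(=O)c1cnc2ccccc2c1Cl`). In an ADME assay on CCRF-CEM cells (Homo sapiens) for cytotoxicity (on this read-out lower numbers stand for higher toxicity in this test and higher numbers for lower toxicity in this test), compound 3 gives > 100 uM as a limit and not a number. Compound 1 (`O=C(NCCCO)c1cnc2ccccc2c1Cl`) gives > 100 uM in this assay as a limit as well. Compound 2 (`O=C(NCCO)c1cnc2ccccc2c1Cl`) gives > 100 uM in the same way, again a limit. All three sit at one limit (the limit of > 100 uM in this assay, at which 3 of the 3 values shown sit), so compound 3 has no readable rank among them.

Compound 4 (`COC(=O)[C@@H](NC(=O)c1cnc2ccccc2c1Cl)C(C)C`) carries isopropyl in place of hydrogen on a saturated chain carbon bound to an amide-type nitrogen and a carbonyl carbon. Among the measured compounds shown here, three measured steps bear on this side chain: (a step that the two limits leave unreadable from compound 1 to compound 2), (a step that the two limits leave unreadable from compound 1 to compound 3) and (a step that the two limits leave unreadable from compound 2 to compound 3). None has a readable size, and none places isopropyl on this carbon, so they offer no size to carry over. The expectation therefore rests on compound 3 at > 100 uM as a limit, and no step beyond the scatter is expected in this assay in either direction. The expected change is a step that the limit leaves unreadable from compound 3 to compound 4 and remains an estimate only. For compound 4 the estimated value is 130 uM with an expected range from 50 uM to 300 uM and a report as a limit is the likeliest outcome.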

Compound 4, half-maximal toxic concentration: 17.6 uM
Beside the measured number, compound 4's estimate is 7.4-fold (0.87 log units) above it; the whole stated range lies above it.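

Isopropyl in place of hydrogen on a saturated chain carbon bound to an amide-type nitrogen and a carbonyl carbon gives, in this assay, an at least 5.6-fold lower number from compound 3 to compound 4 (0.75 log units; beyond the scatter), so a change on this carbon can move the read-out towards higher toxicity in this test. The steps among compound 1, compound 2 and compound 3 cannot be read, which leaves compound 4 as the only compound shown with a number rather than a limit: the limit of > 100 uM in this assay, at which 3 of the 4 values shown sit.
Among the compounds shown here, the size of the new step is open at its upper end, and the single change shows only that this carbon responds to isopropyl, not how the read-out follows the size or shape of the group placed there.

On these data alone, whether a smaller methyl, a longer isobutyl chain or a benzyl group on this carbon would give a similar number remains open, as does the result for the opposite configuration at this carbon. Also open, as far as these compounds go, is whether the read-out of compound 4 holds when a carboxylic acid or a primary amide takes the place of the methyl ester.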